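The source may report more compounds than this note shows. Statements on the series, on what has been measured and on what is new or still open speak of the compounds shown alone.

Measured so far in a functional assay on NRK-49F cells (Rattus norvegicus) for cytotoxicity, read by MTT assay, with a stated time of 24 h (a higher number here means a weaker inhibitor, a lower number a stronger inhibitor), for two compounds
Compound 1 `C/C(=N\NC(=O)/C(C#N)=C/c1ccccc1)c1c(O)c2ccc(O)cc2oc1=O` gives 55500 nM
Compound 2 `COc1ccc(/C=C(\C#N)C(=O)N/N=C(\C)c2c(O)c3ccc(O)cc3oc2=O)cc1OC` gives 45300 nM

Compound 2 at 45300 nM stands level with compound 1, the two values lying within the scatter of each other. Compound 3 `COc1ccc(/C=C(\C#N)C(=O)N/N=C(\C)c2c(O)c3ccc(O)cc3oc2=O)cc1` differs from compound 2 in one place hydrogen in place of methoxy on an aromatic carbon and carries hydrogen in place of methoxy on an aromatic carbon, so that 3,4-dimethoxyphenyl becomes 4-methoxyphenyl.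

Going by the values given here, only one measured step bears on this change. It is a 1.2-fold lower number from compound 1 to compound 2 (0.09 log units; within the scatter) for 3,4-dimethoxyphenyl in place of phenyl. The 4-methoxyphenyl of compound 3 falls between those two groups, whose compounds could not be told apart here. The data hold no other substituent at this place, so the expectation rests on that single step. No step beyond the scatter is therefore expected in this assay for this change, and no direction can be favoured. The expected step is a 1.1-fold higher number from compound 2 to compound 3 (0.04 log units; within the scatter) and it is only an estimate. In this assay the estimate for compound 3 is 50000 nM with a range from 28000 nM to 90000 nM expected for it.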

Compound 3, half-maximal inhibitory concentration: 96100 nM
Beside the measured number, compound 3's estimate is 1.9-fold (0.28 log units) below it, outside the stated range (above it).
By their numbers in this assay, from the lowest: compounds 2, 1 and 3 (each within the scatter of the next, the first and the last beyond it).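

In this assay, going by these compounds alone, the loss of one methoxy, with hydrogen in its place on the aromatic carbon ortho to a methoxy group, gives a 2.1-fold higher number from compound 2 to compound 3 (0.33 log units; beyond the scatter) and is the first step at this position to clear the scatter, though only modestly. The other step into compound 3, a 1.7-fold higher number from compound 1 to compound 3 (0.24 log units; within the scatter), stays within the scatter, as does a 1.2-fold lower number from compound 1 to compound 2 (0.09 log units; within the scatter), so 3,4-dimethoxyphenyl can be told apart from 4-methoxyphenyl while the phenyl of compound 1 cannot be told apart from either, and no steady trend with the number of methoxy groups can be claimed across these compounds. Nothing in the data given accounts for the step from 3,4-dimethoxyphenyl to 4-methoxyphenyl.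

On these data alone, it remains open whether this step is particular to methoxy, which a hydroxy group, a chlorine atom or an amine on the same aromatic carbon would help to settle. Also open, as far as these compounds go, is whether a longer chain on that oxygen, such as ethoxy in place of methoxy, would shift the number in this assay at all.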